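This account rests on a few compounds, and the source may have more. Where it says the series, first, only, none or still open, it means among the compounds named here.

Series notes. Compound 1 `O=C(COC(=O)/C=C/c1ccccc1)NCCC[Te]c1ccccc1` and compound 2 `COc1ccc(N(CC(=O)NCCCSc2ccccc2)C(=O)/C=C/c2ccccc2)cc1` differ in more than one place; how their two cores differ is not broken down here. In a physicochemical assay for lipophilicity, read by HPLC, measured as octanol-water partition (a higher number here means a more lipophilic compound, a lower number a more polar compound), compound 2 gives 4, while compound 1 gives 3.01, the lowest of the three numbers measured. Compound 3 `COc1ccc(N(CC(=O)NCCCSc2ccccc2)C(=O)C#Cc2ccccc2)cc1` is made from compound 2 by 2-phenylethynyl in place of 2-phenylethenyl on a carbonyl carbon; in this assay compound 3 gives 3.4, a step of a number 0.60 log units lower from compound 2 to compound 3 (beyond the scatter). Compound 4 `O=C(COC(=O)C#Cc1ccccc1)NCCC[Te]c1ccccc1` makes the same kind of change on the core of compound 1, (2-phenylethynyl in place of 2-phenylethenyl on a carbonyl carbon). The two places are not identical: in compound 2 the carbonyl carbon's other neighbour is amide-type nitrogen, in compound 1 it is oxygen next to a carbonyl group. The step from compound 1 to compound 4 is expected to be a number 0.56 log units lower from compound 1 to compound 4 (beyond the scatter) in this assay, close to the measured step from compound 2 to compound 3, a number 0.60 log units lower from compound 2 to compound 3 (beyond the scatter), on which the expectation rests; the different neighbour at the place leaves the range somewhat wider. Compound 4 is estimated at 2.45 in this assay, between 2 and 2.9.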

Compound 4, partition coefficient: 0.9
The estimate for compound 4 lay 1.55 log units above the measured number, outside the stated range (below it).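

Series notes, continued. In this assay the change to 2-phenylethynyl in place of 2-phenylethenyl on a carbonyl carbon lowers the number on both cores, with a number 2.11 log units lower from compound 1 to compound 4 (beyond the scatter) set against a number 0.60 log units lower from compound 2 to compound 3 (beyond the scatter), so the direction carried across these two pairs while the size did not. The place differs, with oxygen next to a carbonyl group as the other neighbour in compound 1 and amide-type nitrogen in compound 2, and the two cores differ elsewhere too, so two pairs cannot show whether the neighbour or another part of the core goes with the larger step. Nothing available bears on why the two steps differ in size.

The compounds shown leave open whether the larger step stays when only the neighbour of the carbonyl carbon is exchanged, or when sulfur stands in place of tellurium on the core of compound 1. Also open, on these data alone, is how the same change behaves on a core carrying an amine, a carboxylic acid or a longer chain.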